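The compounds below may be only part of what the source reports. "The series", "measured", "known", "first", "only" and "open" are said of these compounds alone.

Measured so far:
- Compound 1 `Cc1cc(C)c(CN2CCc3c(F)cc(O[C@@H]4CCOC4)c(Cl)c3C2=O)c(=O)[nH]1`: 1030 nM
- Compound 2 `Cc1cc(C)c(CN2CCc3ccc(-c4c(C)noc4C)c(Cl)c3C2=O)c(=O)[nH]1`: 121 nM

In a functional assay on KARPAS-422 cells (Homo sapiens) for inhibition, with a stated time of 72 h (on this read-out higher numbers stand for weaker inhibition and lower numbers for stronger inhibition), compound 1 gives the highest of the two numbers; compound 2 gives a lower number, a gap beyond the scatter. Compound 3 `Cc1cc(C)c(CN2CCc3c(C)cc(O[C@@H]4CCOC4)c(Cl)c3C2=O)c(=O)[nH]1` differs from compound 1 at one place: methyl in place of fluoro on an aromatic carbon. Among the compounds with values here, no pair of measured compounds isolates this change, so the only guide is compound 1 itself. A single small group swapped for another small group is expected to shift the number little, so the step of a 1.3-fold lower number from compound 1 to compound 3 (0.11 log units; within the scatter) is estimated to lie within the scatter. For compound 3 the estimated value is 800 nM, with a range from 300 nM to 2500 nM.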

Compound 3, half-maximal inhibitory concentration in the KARPAS-422 assay: 406 nM
For compound 3 the middle estimate is 2.0-fold (0.29 log units) above the measured one; the range from low to high includes it.
By their numbers in the KARPAS-422 assay, from the lowest: compound 2; then compound 3; then compound 1.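

In the KARPAS-422 assay methyl in place of fluoro on this aromatic carbon gives a 2.5-fold lower number from compound 1 to compound 3 (0.40 log units; beyond the scatter) and so stronger inhibition, which shows that the position responds to swapping one heavy atom for another. In a physicochemical assay for lipophilicity, at pH 7.4 (a lower number here means a more polar compound, a higher number a more lipophilic compound), compound 1 gives 2.1 and compound 3 gives 2.1 and so the change in inhibition comes with no change on that read-out. Nothing measured here explains the step. From the compounds shown here alone, whether ethyl or methoxy on this carbon would lower the number further stays open. So does whether the same swap would act alike without the (oxolan-3-yl)oxy group.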